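A few compounds are considered here, and "the series" means these few. Any claim that something is new, unique, unknown or untested is made for them only; others in the source may bear on it.

In a functional assay on MCF7 cells (Homo sapiens) for cytotoxicity, read by colorimetric assay and MTT assay (a higher number here means a weaker inhibitor, a lower number a stronger inhibitor), compound 1 `COc1ccc(-c2cc3cccc(OC)c3nc2O)cc1` gives 10000 nM and compound 2 `COc1ccc(-c2cc3c(OC)ccc(OC)c3nc2O)cc1` gives 10000 nM. Compound 3 `COc1ccc(-c2cc3c(OC)cc(OC)cc3n(CCCC#N)c2=O)cc1` stands level with both at 10000 nM, so the three measured compounds show the same value.

Compound 4 `CCN(CC)C(=O)CCn1c(=O)c(-c2ccc(OC)cc2)cc2c(OC)cc(OC)cc21` differs from compound 3 in one place: diethylcarbamoyl in place of cyanomethyl on a saturated chain carbon, two bonds along the chain from an aromatic nitrogen. Diethylcarbamoyl takes the place of cyanomethyl on a saturated chain carbon, two bonds along the chain from an aromatic nitrogen. Cut one bond further out, the same difference reads 3-cyanopropyl to 2-(diethylcarbamoyl)ethyl.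

For the measured compounds named here, only one measured step is available, no change at the digits printed from compound 1 to compound 2 (within the scatter), and it puts methoxy in place of hydrogen on an aromatic carbon. Going by the values given here, it therefore bears on the new change only loosely, since no measured pair tests a change in this chain. The data thus give no sign of a shift in either direction, and the expectation starts from compound 3 at 10000 nM. The expected size of the change in this assay is no change at the digits printed from compound 3 to compound 4 (within the scatter), which means none beyond the scatter, although the untested larger group keeps the range wide. Compound 4 is expected at 10000 nM, with an estimated range from 3500 nM to 20000 nM.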

Compound 4, half-maximal inhibitory concentration: 10000 nM
The estimate for compound 4 equals the measured number at the digits printed; measured number inside the range.
By their numbers in this assay, from the lowest: compounds 1, 2, 3 and 4 (each within the scatter of the next).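

In this assay compound 4 gives 10000 nM, and the step on the saturated chain carbon, two bonds along the chain from an aromatic nitrogen, reads no change at the digits printed from compound 3 to compound 4 (within the scatter). For the compounds shown here, the only earlier step concerned methoxy on an aromatic carbon, so this is the first measured pair that tests this chain: cyanomethyl, with 3 heavy atoms and a triple bond, gives way to diethylcarbamoyl, with 7 heavy atoms and a double bond, and the two compounds stand level in this assay. Nothing shown explains this result, and no measurement beyond these values bears on it.

All four compounds stand level, so the data show no group in this set that separates from the others, and this single pair does not show whether any group at this place can move the value in this assay. Going by these compounds, it stays open whether a carboxylic acid or an amine on this chain, or a longer chain ending in diethylcarbamoyl, would read differently from compound 3.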